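The compounds below may be only part of what the source reports. "The series", "measured", "known", "first", "only" and "open" are said of these compounds alone.

Of the compounds shown here, two that share one core have been measured in an ADME assay for permeability, using PAMPA, at pH 7.4; a lower number here means that the compound crosses the layer more slowly, a higher number that the compound crosses the layer faster. Compound 1 `Cc1cc(NC(=O)Nc2ccc(F)cc2)c2ccccc2n1` gives 801 10^-6 cm/s in this assay. Compound 2 `Cc1cc(NC(=O)Nc2ccc(O)cc2)c2ccccc2n1` gives 3 10^-6 cm/s in this assay, the lowest of the two numbers. Going by the values given here, the single measured step between them is a 270-fold lower number from compound 1 to compound 2 (2.43 log units; beyond the scatter). Compound 3 `CC(=O)c1ccc(NC(=O)Nc2cc(C)nc3ccccc23)cc1` is not yet measured; it differs from compound 2 in one place.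

acetyl in place of hydroxy on an aromatic carbon

The hydroxy that entered in the measured step leaves here, so that step bears directly on this one. Where the arrival of the hydroxy went with a large drop, its departure in favour of an acetyl, a group with 0 hydrogen-bond donors, is expected to go with a large rise in this assay, a 67-fold higher number from compound 2 to compound 3 (1.82 log units; beyond the scatter). Compound 3 is therefore expected to give about 200 10^-6 cm/s in this assay, with a likely range from 40 10^-6 cm/s to 800 10^-6 cm/s.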

Compound 3, apparent permeability: 473 10^-6 cm/s
Estimate against measurement, compound 3: 2.4-fold (0.37 log units) below, within the range that was stated.
By their numbers in this assay, from the lowest: compound 2; then compounds 3 and 1 (each within the scatter of the next).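

Replacing the hydroxy with an acetyl gives a 160-fold higher number from compound 2 to compound 3 (2.20 log units; beyond the scatter) in this assay, so the earlier drop can be reversed by a group other than the original fluoro. The change from fluoro to acetyl gives a 1.7-fold lower number from compound 1 to compound 3 (0.23 log units; within the scatter), so two different groups at this place, on a six-membered aromatic ring of carbon only and para to a large group, leave the read-out within the scatter, and among these three compounds the hydroxy of compound 2 alone stands apart. Nothing measured here explains why the hydroxy stands apart. On these data alone, it remains open whether an amine or a carboxylic acid at this place would give a low number like compound 2 or a high one like compounds 1 and 3. A methoxy would test whether the hydroxy's low number survives once its hydrogen is replaced by a methyl.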